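The source may hold more compounds than are shown below. What is called first, only, known or untested is meant among the compounds shown, and "the series" means these compounds.

Working notes on the series. Compound 1 `Cc1cc(OC(C)C)cc(C)c1-c1cccc(COc2ccc(OCC(=O)O)c(F)c2)c1` has no number in a physicochemical assay for lipophilicity, using the shake flask method, in phosphate buffer, measured as octanol-water partition, with a stated time of 24 h, at pH 7.4, tested at 100 uM; on this read-out higher numbers stand for higher lipophilicity and lower numbers for lower lipophilicity: compound 1 stands at "not determined" (no result reported). Two analogues with the same core carry values. Compound 2 `CCOc1cc(C)c(-c2cccc(COc3ccc(OCC(=O)O)c(F)c3)c2)c(C)c1` gives 3.48 in this assay, and compound 3 `Cc1cc(O)cc(C)c1-c1cccc(COc2ccc(OCC(=O)O)c(F)c2)c1` gives 2.37. Going by the values given here, the one measured step, a number 1.11 log units lower from compound 2 to compound 3 (beyond the scatter), is the only comparison that bears on the change in hand. Compound 4 `COCCOc1cc(C)c(-c2cccc(COc3ccc(OCC(=O)O)c(F)c3)c2)c(C)c1` differs from compound 1 as follows: 2-methoxyethyl in place of isopropyl on an oxygen on an aromatic ring. Among the compounds with values here, the 2-methoxyethyl group that enters brings one hydrogen-bond acceptor where isopropyl has none, so a step downward in this assay is expected, smaller than the one from compound 2 to compound 3, which removed the whole alkyl group. For compound 4 the value in this assay is estimated at 3.3, expected between 2.8 and 3.8.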

Compound 4, distribution coefficient: 3.15
Compound 4: the middle estimate sits 0.15 log units above what was measured; low and high end bracket the measured number.
By their numbers in this assay, from the lowest: compound 3; then compound 4; then compound 2.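

In this assay, the 2-methoxyethyl compound falls on neither extreme of this oxygen's series: a number 0.78 log units higher from compound 3 to compound 4 (beyond the scatter) and a number 0.33 log units lower from compound 2 to compound 4 (beyond the scatter) place it apart from both the free hydroxyl and the ethyl ether. Adding methoxy to the chain thus gives a downward step, far smaller than a number 1.11 log units lower from compound 2 to compound 3 (beyond the scatter) when the alkyl group is lost altogether. No measured evidence accounts for either step.

Compound 1 carries no number, so the isopropyl to 2-methoxyethyl change itself cannot be read. Going by these compounds, how an amine or a longer chain on this oxygen would read remains open.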